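This account rests on a few compounds, and the source may have more. Where it says the series, first, only, none or still open, it means among the compounds named here.

Three sulfonamides have been run in an assay on isolated protein for inhibition of malate dehydrogenase, mitochondrial (Sus scrofa), with stated times of 45 min and 30 min; on this read-out higher numbers stand for weaker inhibition and lower numbers for stronger inhibition. Compound 1 `O=S(=O)(Nc1ccc(-c2nc3ccccc3o2)cc1)c1ccc(Cl)c(C(F)(F)F)c1` reaches only the assay limit, > 63000 nM. Compound 2 `Cc1ccc(S(=O)(=O)Nc2ccc(-c3nc4ccccc4o3)cc2)cc1` likewise returns a limit, > 63000 nM. Compound 3 `Cc1ccccc1S(=O)(=O)Nc1ccc2oc(-c3ccccc3)nc2c1` also gives a limit, > 63000 nM. Among the compounds with values here, compound 3 therefore cannot be placed relative to the others: every value shown so far is a limit rather than a number, (the limit of > 63000 nM in this assay, at which 3 of the 3 values shown sit), and no step between measured compounds exists, so the size of any change remains unknown.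

Compound 4 `O=S(=O)(Nc1ccc2oc(-c3ccccc3)nc2c1)c1cccc(F)c1` is the next member. It differs from compound 3 in one place: 3-fluorophenyl in place of 2-methylphenyl on a sulfonyl sulfur. Within the data shown here, no measured step bears on a change of this kind, so the expectation rests only on the fact that all measured members sit at the limit, (the limit of > 63000 nM in this assay, at which 3 of the 3 values shown sit). The step from compound 3 to compound 4 is expected to be none beyond the scatter, a number no higher from compound 3 to compound 4 (the limit leaves the size open). Compound 4 is expected in this assay at 63000 nM, within a range from 30000 nM to 200000 nM, and most probably as a limit once more.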

Compound 4, half-maximal inhibitory concentration: > 63000 nM
Compound 4 was reported as a limit; the forecaster's own chance of this, stated with the estimate: 85%; the middle value sits exactly at the limit.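

In this assay compound 4 returns > 63000 nM, a limit and not a number. Compound 3 also stands at a limit, so no step can be read between compound 3 and compound 4. The compounds shown leave open what concentration gives half-maximal inhibition for any member of the series: the limit of > 63000 nM in this assay, at which 4 of the 4 values shown sit.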